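A few compounds are considered here, and "the series" means these few. Any claim that something is new, unique, unknown or untested is made for them only; others in the source may bear on it.

The measured compounds:
Compound 1 `COc1ccc(-c2cc(=O)c3c(OC)cc(OC)cc3n2Cc2ccccc2)cc1`; in a functional assay on SUP-B15 cells (Homo sapiens) for antiproliferative activity, with a stated time of 72 h (on this read-out higher numbers stand for an effect only at larger amounts of compound and lower numbers for an effect already at smaller amounts), compound 1 gives > 34400 nM, which is a limit of the assay rather than a number.
Compound 2 `C=CCNC(=O)n1c(-c2ccc(OC)cc2)cc(=O)c2c(OC)cc(OC)cc21`; compound 2 gives 16000 nM.
Compound 3 `COC(=O)c1cc(=O)c2c(OC)cc(OC)cc2n1S(=O)(=O)c1ccc(C)cc1`; compound 3 gives 9700 nM.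

Compound 3 and compound 2 sit within the usual scatter of each other, so no order between them can be claimed. Compound 1 contributes only a limit (the limit of > 34400 nM in this assay, at which 1 of the 3 values shown sits).

Compound 4 `COc1ccc(-c2cc(=O)c3c(OC)cc(OC)cc3n2S(=O)(=O)c2ccc(C)cc2)cc1` differs from compound 3 by 4-methoxyphenyl in place of methoxycarbonyl on an aromatic carbon. Among the compounds with values here, the only measured step, an at least 2.1-fold lower number from compound 1 to compound 2 (0.33 log units; beyond the scatter), exchanges the group on the aromatic nitrogen and leaves the aromatic carbon untouched, so it does not bear on this change; no measured pair speaks to a 4-methoxyphenyl replacing a methoxycarbonyl. Within the data shown here, with no relevant step, compound 4 is estimated to fall at 12000 nM, between 4000 nM and 40000 nM. The expected step, a 1.2-fold higher number from compound 3 to compound 4 (0.09 log units; within the scatter), is thus estimated to stay near or only slightly beyond the scatter, with the direction left open.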

Compound 4, half-maximal effective concentration: > 44800 nM
Compound 4: a limit, no number; the forecaster's own chance of this, stated with the estimate: 25%; middle value at least 3.7-fold (0.57 log units) away from the limit.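

In this assay, within the data shown here, a change on the aromatic carbon next to the ring nitrogen can be read for the first time: with (4-methylphenyl)sulfonyl kept on the nitrogen, 4-methoxyphenyl in place of methoxycarbonyl gives an at least 4.6-fold higher number from compound 3 to compound 4 (0.66 log units; beyond the scatter). With 4-methoxyphenyl kept on that carbon, (4-methylphenyl)sulfonyl in place of allylcarbamoyl on the aromatic nitrogen gives an at least 2.8-fold higher number from compound 2 to compound 4 (0.44 log units; beyond the scatter), so the two groups do not simply stand in for each other. Compound 4 gives a limit of the assay and not a number, and the step to it from compound 1, itself a limit, cannot be read: the limit of > 44800 nM in this assay, at which 1 of the 4 values shown sits.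

The compounds shown leave open how a carboxylic acid or a primary amide on that carbon would compare with methoxycarbonyl. They also leave open how methoxycarbonyl behaves with allylcarbamoyl or benzyl on the nitrogen.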